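The compounds below may be only part of what the source reports. "The series", "measured", "known", "first", "only" and "open" are said of these compounds alone.

Measured so far in an ADME assay on RAW264.7 cells (Mus musculus) for cytotoxicity, read by MTT assay, with a stated time of 48 h; a lower number here means a stronger inhibitor, a higher number a weaker inhibitor:
- compound 1 `Clc1ccc2c(NCCCNCc3ccc(-c4ccccc4)s3)ccnc2c1`: 6720 nM
- compound 2 `CC(=O)Nc1ccc(-c2ccc(CNCCCNc3ccnc4cc(Cl)ccc34)s2)cc1`: 2080 nM

Compound 1 gives the highest of the two numbers in this assay. Among the measured compounds shown here, the single step with a substituent added to the terminal phenyl, a 3.2-fold lower number from compound 1 to compound 2 (0.51 log units; beyond the scatter), moved the number down by a modest, beyond-scatter margin.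

Compound 3 `N#Cc1ccc(-c2ccc(CNCCCNc3ccnc4cc(Cl)ccc34)s2)cc1` carries a different substituent at the same kind of position: cyano in place of hydrogen on an aromatic carbon. Only the acetamido step bears on this change, and it gives no direct read on a cyano group. A downward step of similar or smaller size is expected, so that compound 3 is estimated at 3500 nM (range 1500 nM to 8000 nM), a step of a 1.9-fold lower number from compound 1 to compound 3 (0.28 log units; within the scatter).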

Compound 3, half-maximal inhibitory concentration: 3550 nM
The estimate for compound 3 lay 1.0-fold (0.01 log units) below the measured number, within the range that was stated.
By their numbers in this assay, from the lowest: compounds 2, 3 and 1 (each within the scatter of the next, the first and the last beyond it).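

In this assay, the step of a 1.9-fold lower number from compound 1 to compound 3 (0.28 log units; within the scatter) shows that phenyl to 4-cyanophenyl does not separate compound 3 from the unsubstituted compound. The step of a 1.7-fold higher number from compound 2 to compound 3 (0.23 log units; within the scatter) also leaves cyano and acetamido unseparated at this position, so compound 3 cannot be ordered against either neighbour. Nothing available accounts for these numbers.

Open, going by these compounds, is whether an amine or a carboxylic acid on the same aromatic carbon would give a step beyond the scatter. Also open, on these data alone, is how a longer chain in the shared core would read.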